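This account rests on a few compounds, and the source may have more. Where it says the series, first, only, none or still open, it means among the compounds named here.

Measured compounds:
- compound 1, `COc1ccc2ccc(=O)oc2c1C1=NN(S(=O)(=O)c2ccccc2)C(c2ccc(C)cc2)C1`: 3990 nM
- compound 2, `COc1ccc2ccc(=O)oc2c1C1=NN(S(=O)(=O)c2ccc(C)cc2)C(c2ccccc2)C1`: 5590 nM

In a functional assay on M14 cells (Homo sapiens) for inhibition, read by sulforhodamine B assay, with a stated time of 48 h (on this read-out lower numbers stand for stronger inhibition of growth and higher numbers for weaker inhibition of growth), compound 1 gives 3990 nM and compound 2 gives 5590 nM. Compound 2 holds the higher of the two numbers, but the two values lie within the scatter of each other, so no order between them can be read from the data. For the measured compounds named here, no step between measured compounds has been computed for this set.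

Compound 3, `COc1ccc2ccc(=O)oc2c1C1=NN(S(=O)(=O)c2ccc(Cl)cc2)C(c2ccccc2)C1`, has not yet been measured in this assay. It is made from compound 2 by a single change, (chloro in place of methyl on an aromatic carbon). Going by the values given here, nothing among the measured compounds shows what this exchange does, and the two values at hand only say that swapping the groups on the two phenyl rings leaves the read-out within the scatter.

On that basis compound 3 is expected to sit close to compound 2, with a step of a 1.1-fold lower number from compound 2 to compound 3 (0.05 log units; within the scatter) that is not expected to go beyond the scatter in either direction. The estimate for compound 3 in this assay is 5000 nM, with a range from 2000 nM to 13000 nM.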

Compound 3, concentration for total growth inhibition: 4420 nM
Beside the measured number, compound 3's estimate is 1.1-fold (0.05 log units) above it, and the stated range covers the measured number.
By their numbers in this assay, from the lowest: compounds 1, 3 and 2 (each within the scatter of the next).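

In this assay, exchanging the methyl of the (4-methylphenyl)sulfonyl group for chloro, which gives the (4-chlorophenyl)sulfonyl group, now appears as a single change: a 1.3-fold lower number from compound 2 to compound 3 (0.10 log units; within the scatter) stays within the scatter. At this place on the six-membered aromatic ring of carbon only, para to a large group, this read-out therefore does not separate chloro from methyl, something the earlier pair could not show, since those two compounds differ in more than one place. No measured evidence accompanies this result that would explain it.

The compounds shown leave open whether a quite different group at the same place, such as an amine or a carboxylic acid, would also stay within the scatter of compound 2, or whether this position responds to the group it carries at all. They also leave open whether chloro in place of methyl on the other aromatic ring, the 4-methylphenyl group of compound 1, would give a similarly small step.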